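The source may hold more compounds than are shown below. What is called first, only, known or untested is meant among the compounds shown, and "the series" means these compounds.

Measured compounds in a functional assay on MGC-803 cells (Homo sapiens) for antiproliferative activity, read by MTT assay, with a stated time of 72 h; a lower number here means a stronger inhibitor, a higher number a weaker inhibitor:
compound 1 `C/C(=N\NC(=O)c1cccc(S(=O)(=O)N2CCOCC2)c1)c1cccc(O)c1` gives > 100000 nM
compound 2 `C/C(=N\NC(=O)c1cccc(S(=O)(=O)N2CCOCC2)c1)c1ccc(O)cc1` gives 71400 nM
compound 3 `C/C(=N\NC(=O)c1cccc(S(=O)(=O)N2CCOCC2)c1)c1cc(F)ccc1O` gives 2260 nM.

For compound 1 only a limit is known, (the limit of > 100000 nM in this assay, at which 1 of the 3 values shown sits), not a number. Moving the hydroxyl gave an at least 1.4-fold lower number from compound 1 to compound 2 (0.14 log units; that floor lies within the scatter), a step that stays inside the scatter. The pattern with the hydroxyl on the carbon beside the imine-bearing carbon changed matters: an at least 44-fold lower number from compound 1 to compound 3 (1.64 log units; beyond the scatter) and a 32-fold lower number from compound 2 to compound 3 (1.50 log units; beyond the scatter), both large.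

Compound 4 `C/C(=N\NC(=O)c1cccc(S(=O)(=O)N2CCOCC2)c1)c1cccc(N)c1O` carries the change (3-amino-2-hydroxyphenyl in place of 3-hydroxyphenyl on a carbon with a double bond to nitrogen). It shares the 2-hydroxy arrangement of compound 3, and on the strength of an at least 44-fold lower number from compound 1 to compound 3 (1.64 log units; beyond the scatter) a large drop in number is expected for compound 4, of about an at least 16-fold lower number from compound 1 to compound 4 (1.22 log units; beyond the scatter). The value estimated for compound 4 in this assay is 6000 nM, within 1000 nM to 40000 nM.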

Compound 4, half-maximal inhibitory concentration: 530 nM
Compound 4: middle estimate off by 11-fold (1.05 log units), on the high side; measured number outside the range, below it.
By their numbers in this assay, from the lowest: compound 4; then compound 3; then compound 2. At a limit, above all of these: compound 1.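

In this assay, 3-amino-2-hydroxyphenyl on the carbon with a double bond to nitrogen gives a 130-fold lower number from compound 2 to compound 4 (2.13 log units; beyond the scatter), and also an at least 180-fold lower number from compound 1 to compound 4 (2.27 log units; beyond the scatter). That second step is only a floor, compound 1 being known as a limit and not a number: the limit of > 100000 nM in this assay, at which 1 of the 4 values shown sits. The new point is that the 2-hydroxy arrangement does not set the number alone, since the other group on the ring also counts: a 4.3-fold lower number from compound 3 to compound 4 (0.63 log units; beyond the scatter).

Open, going by these compounds, is how a plain 2-hydroxyphenyl would compare with these two groups. Also open, on these data alone, is how a dimethylamino or acetamide group would compare in place of the amino group.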